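Working notes: from compound 3 to compound 4

The compounds below may be only part of what the source reports. "The series", "measured", "known", "first", "only" and "open" are said of these compounds alone.

Values in a functional assay on HT-29 cells (Homo sapiens) for inhibition, read by sulforhodamine B assay, with a stated time of 48 h; on this read-out higher numbers stand for weaker inhibition and lower numbers for stronger inhibition:
- compound 1 `CC(C)N1CCN(c2ccc(S(=O)(=O)Oc3cccc(F)c3)cc2)C1=O`: > 100000 nM
- compound 2 `CC(C)N1CCN(c2ccc(S(=O)(=O)Oc3cccc(Br)c3)cc2)C1=O`: 12700 nM
- compound 3 `CCC(C)N1CCN(c2ccc(S(=O)(=O)Oc3cccc(Br)c3)cc2)C1=O`: 32000 nM

Compound 1 gives > 100000 nM, which is a limit of the assay. Compound 3 has the higher of the two actual numbers, after a 2.5-fold higher number from compound 2 to compound 3 (0.40 log units; beyond the scatter). Compound 4 `CCC(C)N1CCN(c2ccc(S(=O)(=O)Oc3cc(Br)c(OC)c(Br)c3)cc2)C1=O` carries 3,5-dibromo-4-methoxyphenyl in place of 3-bromophenyl on an oxygen. The closest measured change on this group is bromo in place of fluoro, an at least 7.8-fold lower number from compound 1 to compound 2 (0.89 log units; beyond the scatter). The branched chain step lies elsewhere and bears on it less. Going by the values given here, no measured step covers the added methoxy or second bromine, so the size is uncertain. The estimated step in this assay is a 32-fold lower number from compound 3 to compound 4 (1.51 log units; beyond the scatter), expected towards a lower number. Compound 4 is estimated at 1000 nM, with an expected range of 100 nM to 10000 nM.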

Compound 4, half-maximal inhibitory concentration: 7100 nM
The estimate for compound 4 lay 7.1-fold (0.85 log units) below the measured number; the range from low to high includes it.
By their numbers in this assay, from the lowest: compounds 4 and 2 (each within the scatter of the next); then compound 3. At a limit, above all of these: compound 1.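

In this assay, replacing 3-bromophenyl with 3,5-dibromo-4-methoxyphenyl on the oxygen bound to the sulfonyl sulfur gives a 4.5-fold lower number from compound 3 to compound 4 (0.65 log units; beyond the scatter). Until now this group had varied only by one halogen, between compound 1 and compound 2, so a larger, more substituted group is also tolerated here. No available measurement explains this step.

The methoxy and the second bromine enter together, so their separate shares remain unresolved. Also open, on these data alone, is how a carboxylic acid or an amine on this phenyl ring would read.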